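Trifluoromethyl for Nitro, Tried on a Second Core

This account rests on a few compounds, and the source may have more. Where it says the series, first, only, none or still open, it means among the compounds named here.

Measured so far:
Compound 1, `COc1cc(O)cc(O)c1C(=O)/C=C/c1ccc([N+](=O)[O-])cc1`, gives > 50000 nM, which is a limit of the assay rather than a number.
Compound 2, `COc1cc(O)cc(O)c1C(=O)/C=C/c1ccc(C(F)(F)F)cc1`, gives 9500 nM.
Compound 3, `COc1cc(OC)c(C(=O)/C=C/c2ccc([N+](=O)[O-])cc2)c(OC)c1`, gives 8000 nM.

All three were tested in a functional assay on HeLa cells (Homo sapiens) for inhibition, read by MTT assay, with a stated time of 72 h; a higher number here means a weaker inhibitor, a lower number a stronger inhibitor. Compound 1 and compound 2 share a core and differ in one place: trifluoromethyl in place of nitro on an aromatic carbon. This change gave an at least 5.2-fold lower number from compound 1 to compound 2 (0.72 log units; beyond the scatter); the step is stated only as a lower bound because of the limit of > 50000 nM in this assay, at which 1 of the 3 values shown sits. Compound 3 carries a different core, and how its core differs from that of compound 1 is not broken down here. Compound 4, `COc1cc(OC)c(C(=O)/C=C/c2ccc(C(F)(F)F)cc2)c(OC)c1`, has not yet been measured; it differs from compound 3 by the same change, (trifluoromethyl in place of nitro on an aromatic carbon). The step expected here is a 5.3-fold lower number from compound 3 to compound 4 (0.73 log units; beyond the scatter), resting on an at least 5.2-fold lower number from compound 1 to compound 2 (0.72 log units; beyond the scatter). Compound 4 is therefore estimated at 1500 nM in this assay, most likely between 400 nM and 6000 nM.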

Compound 4, half-maximal inhibitory concentration: 5100 nM
The estimate for compound 4 lay 3.4-fold (0.53 log units) below the measured number; the range from low to high includes it.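

Moved to a second core, trifluoromethyl in place of nitro gave a 1.6-fold lower number from compound 3 to compound 4 (0.20 log units; within the scatter) in this assay, so the clear gain seen on the first core did not carry over, and the two steps differ: the same change on two cores in this assay, an at least 5.2-fold lower number (0.72 log units; beyond the scatter) from compound 1 to compound 2 and a 1.6-fold lower number (0.20 log units; within the scatter) from compound 3 to compound 4, at least 3.3-fold (0.52 log units) apart, beyond the scatter of two such steps. Compound 1 gives > 50000 nM, which is a limit and not a number, so the first step is known only as a lower bound. Two cores cannot show which feature of a core sets the size of this step, or how the change would behave on any other core.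

The compounds shown leave open how an amine or a carboxylic acid would compare on the same aromatic carbon. They also leave open whether such a group would behave alike on both cores.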